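Metabolic stability across changes at the aryl position

The source may hold more compounds than are shown below. What is called first, only, known or untested is meant among the compounds shown, and "the series" means these compounds.

In an ADME assay on microsomes from liver (Homo sapiens) for metabolic stability, read by LC-MS, tested at 1 mM (on this read-out lower numbers stand for a shorter-lived compound and higher numbers for a longer-lived compound), compound 1 `N#Cc1ccc(F)cc1Cn1c(N2CCC[C@@H](N)C2)nc2c(-c3cccs3)c[nH]c2c1=O` gives 0.585 h, and compound 2 `N#Cc1ccc(F)cc1Cn1c(N2CCC[C@@H](N)C2)nc2c(-c3ccc(F)cc3)c[nH]c2c1=O` gives 3.01 h. Among the measured compounds shown here, compound 2 thus stands highest of the two numbers measured so far; the only step recorded in this assay is a 5.1-fold higher number from compound 1 to compound 2 (0.71 log units; beyond the scatter). Compound 3 `N#Cc1ccc(F)cc1Cn1c(N2CCC[C@@H](N)C2)nc2c(F)c[nH]c2c1=O` is not yet measured. It differs from compound 2 by fluoro in place of 4-fluorophenyl on an aromatic carbon. For the measured compounds named here, the one measured step exchanges thiophen-2-yl for 4-fluorophenyl, one aromatic ring for another; no measured step replaces a ring at this carbon with a single atom, so it bears on compound 3 only loosely. Because a 5.1-fold higher number from compound 1 to compound 2 (0.71 log units; beyond the scatter) shows that the group on this carbon can shift the number beyond the scatter, a shift in either direction is possible, and a small downward step is expected, a 2.0-fold lower number from compound 2 to compound 3 (0.30 log units; within the scatter). Compound 3 is therefore estimated at 1.5 h, with a range from 0.5 h to 4.5 h.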

Compound 3, half-life: 1.64 h
Estimate against measurement, compound 3: 1.1-fold (0.04 log units) below; the range from low to high includes it.
By their numbers in this assay, from the lowest: compound 1; then compounds 3 and 2 (each within the scatter of the next).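

In this assay, the aromatic ring at this carbon is shown not to be required: with fluoro in place of 4-fluorophenyl there is a 1.8-fold lower number from compound 2 to compound 3 (0.26 log units; within the scatter), so a single atom and the much larger ring cannot be told apart on this read-out. Thiophen-2-yl is now the group that stands apart, since fluoro also gives a 2.8-fold higher number from compound 1 to compound 3 (0.45 log units; beyond the scatter), and this adds to the earlier comparison with 4-fluorophenyl alone. Among these three compounds, the separation therefore lies between compound 1 and the other two, with no trend in the size of the group. No measurement here bears on the cause of this separation.

Open, from the compounds shown here alone, is whether furan-2-yl, another five-membered aromatic ring, would sit with thiophen-2-yl or with fluoro and 4-fluorophenyl. Also open, going by these compounds, is how an amine or a carboxylic acid on this carbon would compare with fluoro.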